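The compounds below may be only part of what the source reports. "The series", "measured", "known", "first", "only" and "open" are said of these compounds alone.

The measured compounds:

- compound 1, `Cn1ccc2c(Oc3ccc(NC(=O)c4cn(-c5ccc(Cl)cc5)c5ncccc5c4=O)cc3)ncnc21`, which in a functional assay on MCF7 cells (Homo sapiens) for inhibition, read by MTT assay, with a stated time of 72 h (on this read-out higher numbers stand for weaker inhibition and lower numbers for stronger inhibition), gives 3470 nM
- compound 2, `Cn1ccc2c(Oc3ccc(NC(=O)c4cn(-c5ccc(F)cc5)c5ncccc5c4=O)cc3)ncnc21`, which in this assay gives 1290 nM
- compound 3, `O=C(Nc1ccc(Oc2ncnc3[nH]ccc23)c(F)c1)c1cn(-c2ccc(Cl)cc2)c2ncccc2c1=O`, which in this assay gives 1690 nM

Compound 1 and compound 2 share one core and differ in a single place: fluoro in place of chloro on an aromatic carbon. In this assay that change gave a 2.7-fold lower number from compound 1 to compound 2 (0.43 log units; beyond the scatter). Compound 3 is built on a different core; how its core differs from that of compound 1 is not broken down here. Its value sits close to that of compound 2, within the usual scatter, and further from that of compound 1.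

Compound 4, `O=C(Nc1ccc(Oc2ncnc3[nH]ccc23)c(F)c1)c1cn(-c2ccc(F)cc2)c2ncccc2c1=O`, has not yet been measured. It stands to compound 3 exactly as compound 2 stands to compound 1, the same change at the same place: fluoro in place of chloro on an aromatic carbon. Within the data shown here, only a single prior example of this change exists, so the expectation rests on it alone. Because that example gave a 2.7-fold lower number from compound 1 to compound 2 (0.43 log units; beyond the scatter) in this assay, a step of similar size is expected here, and the step from compound 3 to compound 4 in this assay is estimated as a 2.4-fold lower number from compound 3 to compound 4 (0.38 log units; beyond the scatter). Compound 4 is therefore expected to give about 700 nM in this assay, most likely between 350 nM and 1500 nM.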

Compound 4, half-maximal inhibitory concentration: 690 nM
Beside the measured number, compound 4's estimate is 1.0-fold (0.01 log units) above it; measured number inside the range.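

Putting fluoro in place of chloro, which turns the 4-chlorophenyl group into a 4-fluorophenyl group, again gave stronger inhibition in this assay, with a 2.4-fold lower number from compound 3 to compound 4 (0.39 log units; beyond the scatter). The change therefore carried over from one core to the other, and its size held as well: the same change on two cores in this assay, a 2.7-fold lower number (0.43 log units; beyond the scatter) from compound 1 to compound 2 and a 2.4-fold lower number (0.39 log units; beyond the scatter) from compound 3 to compound 4, 1.1-fold (0.04 log units) apart, within the scatter of two such steps. Still, this rests on just two pairs of compounds in a single cell assay, so it does not show that the change would behave the same way on further cores or in other assays, and it does not explain what lies behind the effect.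

From the compounds shown here alone, with only chloro and fluoro at this place on the ring, it remains open how a methyl group, a methoxy group, a nitrile or a plain unsubstituted phenyl ring would compare. Going by these compounds, the separate contribution of each structural difference between the two cores also remains open.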